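This account rests on a few compounds, and the source may have more. Where it says the series, first, only, none or still open, it means among the compounds named here.

Measured so far:
compound 1 `Cc1cc(-c2ccc(Cl)cc2)c(S(C)(=O)=O)cc1C(=O)N=C(N)N` gives 45 nM in a functional assay for inhibition of sodium/hydrogen exchanger (Oryctolagus cuniculus); on this read-out lower numbers stand for stronger inhibition and higher numbers for weaker inhibition
compound 2 `Cc1cc(N2CCCC2)c(S(C)(=O)=O)cc1C(=O)N=C(N)N` gives 11 nM in this assay

Compound 2 stands lowest of the two numbers shown; the one measured step, a 4.1-fold lower number from compound 1 to compound 2 (0.61 log units; beyond the scatter), is beyond the scatter and separates it from compound 1, the nearest and only other point.

Compound 3 `Cc1cc(Oc2cccnc2)c(S(C)(=O)=O)cc1C(=O)N=C(N)N` is not yet measured. Its change from compound 2 is (pyridin-3-yl)oxy in place of pyrrolidin-1-yl on an aromatic carbon. Going by the values given here, the only measured step that bears on this change is a 4.1-fold lower number from compound 1 to compound 2 (0.61 log units; beyond the scatter), where a group with a six-membered aromatic ring, 4-chlorophenyl, on that carbon gave the higher number and pyrrolidin-1-yl the lower. Among the compounds with values here, the entering (pyridin-3-yl)oxy again brings a six-membered aromatic ring, though with one hetero atom in the ring and an added oxygen, and no measured pair shows such a group at this carbon. The step that is therefore expected is a 3.2-fold higher number from compound 2 to compound 3 (0.50 log units; beyond the scatter), a move back toward the number of compound 1 of a size comparable to that measured step and uncertain in both directions. For compound 3 the estimate in this assay is 35 nM, with a range from 12 nM to 110 nM.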

Compound 3, half-maximal inhibitory concentration: 8.8 nM
Estimate against measurement, compound 3: 4.0-fold (0.60 log units) above, and the stated range ends above it.
By their numbers in this assay, from the lowest: compounds 3 and 2 (each within the scatter of the next); then compound 1.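

In this assay, the change from pyrrolidin-1-yl to (pyridin-3-yl)oxy on this aromatic carbon, ortho to the methylsulfonyl group, gives a 1.3-fold lower number from compound 2 to compound 3 (0.10 log units; within the scatter), so these two groups cannot be told apart here despite their different rings. Against 4-chlorophenyl, the same (pyridin-3-yl)oxy group gives a 5.1-fold lower number from compound 1 to compound 3 (0.71 log units; beyond the scatter), so a six-membered aromatic ring at this carbon does not in itself go with the higher number of compound 1, and compound 3 goes against any such reading of the earlier step. Nothing available gives a reason for either of these steps.

The compounds shown leave open whether the oxygen link, the ring nitrogen or the loss of the chlorine accounts for the separation from compound 1, a question that phenoxy, directly attached pyridin-3-yl and unsubstituted phenyl at the same carbon would address. Also open, from the compounds shown here alone, is how far this carbon tolerates groups of other kinds, such as an open-chain dimethylamino group, a piperidin-1-yl ring or a carboxylic acid, in comparison with compound 2 and compound 3.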